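Removing One Methyl Group From Compound 2

This account rests on a few compounds, and the source may have more. Where it says the series, first, only, none or still open, it means among the compounds named here.

In a functional assay on HCT-116 cells (Homo sapiens) for inhibition, read by MTT assay, with a stated time of 72 h (a lower number here means a stronger inhibitor, a higher number a weaker inhibitor), compound 1 `O=C1C=CC(O)(c2cc3ccccc3n2S(=O)(=O)c2ccccc2)C=C1` gives 30 nM. Compound 2 `COC(=O)CCc1ccc(S(=O)(=O)n2c(C3(O)C=CC(=O)C=C3)cc3ccccc32)cc1` carries a 2-(methoxycarbonyl)ethyl group in place of a hydrogen on an aromatic carbon and gives 30 nM, which places it level with compound 1. Within the data shown here, the only measured step in this small set is no change at the digits printed from compound 1 to compound 2 (within the scatter).

Compound 3 `O=C1C=CC(O)(c2cc3ccccc3n2S(=O)(=O)c2ccc(CCC(=O)O)cc2)C=C1` changes just the end of that added chain: hydrogen in place of methyl on an oxygen next to a carbonyl group. Hydrogen takes the place of methyl on an oxygen next to a carbonyl group, so methoxycarbonyl becomes carboxy. Among the measured compounds shown here, no measured step covers this exchange, and the one available step bears on it only indirectly. It shows that the ester-bearing chain can be added with no visible loss, but it says nothing about the free acid. The direction is therefore a cautious judgement: a modest move toward weaker inhibition in this assay is expected, although no change beyond the scatter remains possible. The expected size of the step is a 3.3-fold higher number from compound 2 to compound 3 (0.52 log units; beyond the scatter). Compound 3 is estimated at 100 nM, with an expected range from 30 nM to 500 nM.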

Compound 3, half-maximal inhibitory concentration: 30 nM
Beside the measured number, compound 3's estimate is 3.3-fold (0.52 log units) above it, within the range that was stated.
By their numbers in this assay, from the lowest: compounds 1, 2 and 3 (each within the scatter of the next).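

In this assay, among these compounds, replacing methoxycarbonyl with carboxy at the end of the chain gives no change at the digits printed from compound 2 to compound 3 (within the scatter) and so shows that the free acid reads level with the methyl ester, which the earlier compounds could not show. Placing 2-carboxyethyl in place of hydrogen on an aromatic carbon gives no change at the digits printed from compound 1 to compound 3 (within the scatter) in this comparison, so this position has now taken the chain with either ending while the reading stays level with that of compound 1. No measurement here offers an explanation for these level readings.

What the compounds shown leave open is whether other endings on the same chain, such as an amine or an amide, would also read level, and whether a longer chain would do the same. From the compounds shown here alone, it also remains open whether a carboxylic acid set directly on that aromatic carbon, without the chain, would match compound 3, so how much this position can take before the reading moves is still unknown.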